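This account rests on a few compounds, and the source may have more. Where it says the series, first, only, none or still open, it means among the compounds named here.

Three compounds that share one core, each carrying an acid-bearing chain and a hydroxyl-bearing side arm ending in an aromatic ring, have been tested in an assay on HEK293 cells for binding affinity to prostaglandin E2 receptor EP4 subtype (Rattus norvegicus); a lower number here means a stronger inhibitor, a higher number a weaker inhibitor. Compound 1 `O=C(O)CCCCCCN1C(=O)CC[C@@H]1CC[C@@H](O)CCc1ccccc1` gives 2710 nM in this assay. Compound 2 `O=C(O)c1ccc(CCCN2C(=O)CC[C@@H]2CC[C@@H](O)Cc2cccc(Cl)c2)s1` gives 1.1 nM. Compound 3 `O=C(O)CCCCCCN1C(=O)CC[C@@H]1CC[C@@H](O)Cc1cccc(-c2ccccc2)c1` gives 337 nM, the second highest of the three numbers; compound 1 sits clearly higher and compound 2 far lower, and both gaps lie beyond the usual scatter of repeated measurements.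

Compound 4 `N#Cc1cccc(C[C@H](O)CC[C@H]2CCC(=O)N2CCCCCCC(=O)O)c1` has not yet been measured in this assay. It differs from compound 3 in a single place: cyano in place of phenyl on an aromatic carbon. Going by the values given here, none of the measured compounds differ from one another in only one place, so no measured single step exists to lean on. What the numbers do show is that a small substituent on the aromatic ring is present in compound 2, which gives 1.1 nM, whereas the bulkier two-ring arrangement of compound 3 gives 337 nM. On that basis the change is expected to lower the number, with a step of a 3.4-fold lower number from compound 3 to compound 4 (0.53 log units; beyond the scatter) that is judged to lie beyond the scatter. Compound 4 is therefore estimated at 100 nM, with a likely range from 20 nM to 500 nM.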

Compound 4, half-maximal inhibitory concentration: 388 nM
Compound 4: middle estimate off by 3.9-fold (0.59 log units), on the low side; measured number inside the range.
By their numbers in this assay, from the lowest: compound 2; then compounds 3 and 4 (each within the scatter of the next); then compound 1.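

In this assay, the step of a 1.2-fold higher number from compound 3 to compound 4 (0.06 log units; within the scatter) shows that on this aromatic carbon a phenyl ring of 6 heavy atoms and a cyano group of 2 heavy atoms, the latter with a hydrogen-bond acceptor, cannot be told apart, so neither the ring nor the acceptor changes the reading here. The arm as a whole does register: with 3-cyanophenyl in place of benzyl on the saturated chain carbon, two bonds along the chain from an oxygen on a saturated carbon, the step is a 7.0-fold lower number from compound 1 to compound 4 (0.84 log units; beyond the scatter), a modest change that lies beyond the scatter. Nothing measured here explains either of these two results.

Still open, on these data alone, is whether the same level would hold with a methoxy group, an amine or plain hydrogen on that aromatic carbon, and hydrogen in particular would test whether a group there matters at all. Also open, as far as these compounds go, is whether cyano and phenyl would still match if the arm were paired with the acid-bearing chain of compound 2 instead of the straight chain of compound 3.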